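From furan-3-yl to 1-benzofuran-2-yl at the assay limit

A few compounds are considered here, and "the series" means these few. Any claim that something is new, unique, unknown or untested is made for them only; others in the source may bear on it.

Compound 1 `CNc1ncnc2c1c(-c1ccoc1)cn2[C@@H]1O[C@H](CO)[C@@H](O)[C@H]1O` is reported in a functional assay on A549 cells (Homo sapiens), read by MTT assay, with a stated time of 72 h (on this read-out higher numbers stand for weaker inhibition and lower numbers for stronger inhibition), only as a limit, > 20000 nM. Compound 2 `Cc1ncnc2c1c(-c1ccoc1)cn2[C@@H]1O[C@H](CO)[C@@H](O)[C@H]1O` is likewise reported in this assay only as a limit, > 20000 nM. Compound 2 therefore has no exact number, and its standing is shared with compound 1: the limit of > 20000 nM in this assay, at which 2 of the 2 values shown sit. Among the compounds with values here, the single measured step, a step that the two limits leave unreadable from compound 1 to compound 2, puts methyl in place of methylamino on an aromatic carbon. That step cannot be sized, and it lies at a different place from the change considered here.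

Compound 3 `Cc1ncnc2c1c(-c1cc3ccccc3o1)cn2[C@@H]1O[C@H](CO)[C@@H](O)[C@H]1O` keeps the methyl of compound 2 and alters the other group: 1-benzofuran-2-yl in place of furan-3-yl on an aromatic carbon. The entering 1-benzofuran-2-yl adds a six-membered aromatic ring of carbon only to the five-membered aromatic ring with 1 hetero atom. Within the data shown here, no measured step touches this place, so no size carries over and the data point in no direction. The estimated step, a number no higher from compound 2 to compound 3 (the limit leaves the size open), is expected to stay within the scatter. Another limit is the likeliest report in this assay. Should a number appear, the expected value for compound 3 is 20000 nM, with an estimated range from 6000 nM to 40000 nM.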

Compound 3, half-maximal inhibitory concentration: > 20000 nM
Compound 3: only a limit was reported (the forecaster's own chance of this, stated with the estimate: 75%); the middle value sits exactly at the limit.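

In this assay, compound 3 is reported only as a limit, > 20000 nM. Within the data shown here, compound 2 and compound 3 both stand as limits, so no step between them can be read. The compounds shown leave open how strongly each inhibits and whether either change moves the read-out at all, and all share one standing: the limit of > 20000 nM in this assay, at which 3 of the 3 values shown sit.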